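The source may report more compounds than this note shows. Statements on the series, on what has been measured and on what is new or still open speak of the compounds shown alone.

Measured so far in a functional assay on LOX IMVI cells (Homo sapiens) for cytotoxicity, read by MTT assay, with a stated time of 24 h; on this read-out higher numbers stand for weaker inhibition and lower numbers for stronger inhibition:
- compound 1 `COc1cc(-c2nc(-c3ccccc3)[nH]c2-c2ccnc(NCCCNS(=O)(=O)c3ccc(Br)cc3)n2)ccc1F` gives 33900 nM
- compound 2 `COc1cc(-c2nc(-c3ccccc3)[nH]c2-c2ccnc(NCCCNS(=O)(=O)c3ccccc3)n2)ccc1Cl` gives 7470 nM
- compound 3 `COc1cc(-c2nc(-c3ccccc3)[nH]c2-c2ccnc(NCCCNS(=O)(=O)c3ccc(Cl)cc3)n2)ccc1Cl` gives 60900 nM

In this assay compound 3 lies within the scatter of compound 1 and well above compound 2 on the numbers shown. Compound 4 `COc1cc(-c2nc(-c3ccccc3)[nH]c2-c2ccnc(NCCCNS(=O)(=O)c3ccc(Br)cc3)n2)ccc1Cl` is compound 3 with bromo in place of chloro on an aromatic carbon, para to a large group, so that 4-chlorophenyl becomes 4-bromophenyl bromo in place of chloro on an aromatic carbon and nothing else changes. Going by the values given here, the only measured step at this place is an 8.2-fold higher number from compound 2 to compound 3 (0.91 log units; beyond the scatter) for chloro in place of hydrogen, which is beyond the scatter but does not compare the two halogens. Compound 1 already carries the 4-bromophenyl group, with fluoro rather than chloro on the other ring, and its 33900 nM stays within the scatter of compound 3. The expected change is therefore small, a 1.2-fold lower number from compound 3 to compound 4 (0.09 log units; within the scatter), with no step beyond the scatter anticipated. For compound 4 the estimated value is 50000 nM, with an expected range from 20000 nM to 110000 nM in this assay.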

Compound 4, half-maximal inhibitory concentration: 23700 nM
Compound 4: the middle estimate sits 2.1-fold (0.32 log units) above what was measured; measured number inside the range.
By their numbers in this assay, from the lowest: compound 2; then compounds 4, 1 and 3 (each within the scatter of the next, the first and the last beyond it).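

In this assay the two halogens at this place are not interchangeable: bromo in place of chloro gives a 2.6-fold lower number from compound 3 to compound 4 (0.41 log units; beyond the scatter) with nothing else altered. Bromo in place of hydrogen still gives a 3.2-fold higher number from compound 2 to compound 4 (0.50 log units; beyond the scatter) so the 4-bromophenyl group, like the 4-chlorophenyl group, stands above the unsubstituted phenyl of compound 2 on this read-out. With 4-bromophenyl kept, chloro in place of fluoro on the other side of the molecule gives a 1.4-fold lower number from compound 1 to compound 4 (0.16 log units; within the scatter) and so leaves the number within the scatter.

The compounds shown leave open how a methoxy group, an amine or a carboxylic acid at this place would compare with these halogens, and whether a longer chain would alter the halogen step. Nothing measured here explains the difference between bromo and chloro.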